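One Swap, Two Cores: Estimating an Antiproliferative Value

The source may hold more compounds than are shown below. What is called first, only, known or untested is meant among the compounds shown, and "the series" means these compounds.

Of the compounds shown here, three with closely related scaffolds have been tested in a functional assay on Bel-7402 cells (Homo sapiens) for antiproliferative activity, read by MTT assay, with a stated time of 72 h; a lower number here means a stronger inhibitor, a higher number a weaker inhibitor. Compound 1 `Cc1ccc(NC2=C/C(=N/NC(N)=S)C(=O)N=C2Nc2ccc(C)cc2)cc1` gives 4330 nM in this assay. Compound 2 `NC(=S)N/N=C1/C=C(Nc2ccc(Cl)cc2)C(Nc2ccc(Cl)cc2)=NC1=O` carries a different core; how its core differs from that of compound 1 is not broken down here. In this assay compound 2 gives 820 nM, the lowest of the three numbers. Compound 3 `Cc1ccc(NC2=C/C(=N/N=C(\N)SCc3ccccc3)C(=O)N=C2Nc2ccc(C)cc2)cc1` differs from compound 1 in one place, (a group of 11 heavy atoms (8 carbon, 2 nitrogen, 1 sulfur; one six-membered aromatic ring of carbon only) in place of a group of 4 heavy atoms (1 carbon, 2 nitrogen, 1 sulfur; no ring), on a double-bonded nitrogen), and in this assay compound 3 gives 7680 nM, a step of a 1.8-fold higher number from compound 1 to compound 3 (0.25 log units; within the scatter).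

Compound 4 `N/C(=N\N=C1\C=C(Nc2ccc(Cl)cc2)C(Nc2ccc(Cl)cc2)=NC1=O)SCc1ccccc1` has not yet been measured. It relates to compound 2 exactly as compound 3 relates to compound 1: a group of 11 heavy atoms (8 carbon, 2 nitrogen, 1 sulfur; one six-membered aromatic ring of carbon only) in place of a group of 4 heavy atoms (1 carbon, 2 nitrogen, 1 sulfur; no ring), on a double-bonded nitrogen. The surroundings of the change are the same in both pairs, so it is the same change. Because this change produced only a 1.8-fold higher number from compound 1 to compound 3 (0.25 log units; within the scatter), a step of similar size is expected from compound 2 to compound 4, namely a 1.8-fold higher number from compound 2 to compound 4 (0.26 log units; within the scatter). The expectation rests on a single prior example and so carries real uncertainty. Compound 4 is therefore estimated at 1500 nM in this assay, with a likely range from 600 nM to 4000 nM.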

Compound 4, half-maximal inhibitory concentration: 17300 nM
Estimate against measurement, compound 4: 12-fold (1.06 log units) below; measured number above the stated range.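

On the core of compound 2, the swap gives a 21-fold higher number from compound 2 to compound 4 (1.32 log units; beyond the scatter), so a change that made no clear difference on the core of compound 1 brings a large loss of activity here. The size of a step measured on one core therefore did not carry over to the other, even though the change and its immediate surroundings are the same: the same change on two cores in this assay, a 1.8-fold higher number (0.25 log units; within the scatter) from compound 1 to compound 3 and a 21-fold higher number (1.32 log units; beyond the scatter) from compound 2 to compound 4, 12-fold (1.08 log units) apart, beyond the scatter of two such steps

Within the data shown here, only one of the two steps lies beyond the scatter, and two pairs show neither which feature of the cores separates them nor how the change would behave on any other core.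

The compounds shown leave open whether a small group such as methyl, or a longer alkyl chain without an aromatic ring, would bring the same large step on the core of compound 2. They also leave open how the step would behave on a related core carrying fluorine or a methoxy group.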